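The source may hold more compounds than are shown below. What is called first, only, known or untested is meant among the compounds shown, and "the series" means these compounds.

Three compounds set the scene so far, all tested in a functional assay on COR-L23 cells (Homo sapiens) for antiproliferative activity, read by CellTiter-Glo, with a stated time of 4 days; a higher number here means a weaker inhibitor, a lower number a stronger inhibitor. Compound 1 `O=C(NCc1cccnc1)Nc1ccc(CN2C(=O)c3ccccc3C2=O)cc1` has the entry "not determined" (no result reported), so it offers nothing to compare. Compound 2 `O=C(CCc1cccnc1)Nc1ccc(CN2C(=O)c3ccccc3C2=O)cc1` reads > 10000 nM, which is a limit of the assay and not a number. For the measured compounds named here, compound 3 `O=C(N[C@@H](CO)c1ccc(NC(=O)[C@H]2C[C@@H]2c2cccnc2)cc1)c1ccccc1` gives 630 nM, the only true number available, so it stands alone as the single reference point in this assay.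

The next compound, compound 4 `C[C@H](NC(=O)c1ccccc1)c1ccc(NC(=O)[C@H]2C[C@@H]2c2cccnc2)cc1`, is a close relative of compound 3. The change is hydrogen in place of hydroxy on a saturated chain carbon, two bonds along the chain from an amide-type nitrogen and an aromatic carbon. The same difference can be read as hydroxymethyl to methyl, while the rest of the structure stays as it was.

Going by the values given here, no two measured compounds differ in only one place, so there is no measured step to judge this change by. The best expectation is a modest shift, probably no larger than the scatter of repeat measurements, with only a slight lean towards a lower number. The expected change is a 1.6-fold lower number from compound 3 to compound 4 (0.20 log units; within the scatter). Compound 4 is estimated at 400 nM, with an expected range of 100 nM to 1500 nM.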

Compound 4, half-maximal inhibitory concentration: 8 nM
For compound 4 the middle estimate is 50-fold (1.70 log units) above the measured one; measured number below the stated range.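

For the compounds shown here, this is the first measured step in this assay, and it shows that this position is far from indifferent: a 79-fold lower number from compound 3 to compound 4 (1.90 log units; beyond the scatter), a large change for hydrogen in place of hydroxy on a saturated chain carbon, with the rest of the structure untouched. Compound 1 has no result and compound 2 carries only a limit of the assay, so neither could show how much a single small edit can matter in this series. Nothing measured here accounts for the size of this step.

One step at one position cannot separate what the hydroxy itself contributes from what any other group on that carbon might do, so the reading of hydroxymethyl to methyl stays a single observation and not a trend. Going by these compounds, how an aminomethyl, a carboxylic acid, a methoxymethyl, a fluorine or a longer chain such as ethyl would fare at the same place remains open, as does whether the same edit would have a similar effect on a different core.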